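Swapping the dimethoxyphenyl for nitrophenyl: what to expect

The source may report more compounds than this note shows. Statements on the series, on what has been measured and on what is new or still open speak of the compounds shown alone.

Compound 1 `COc1ccc(C2N=C(SCc3ccccc3Cl)NC(C)=C2C(=O)Nc2ccc(F)cc2)cc1OC`: 21%
Compound 2 `COc1ccc(C2N=C(SCc3ccc(F)cc3)NC(C)=C2C(=O)Nc2ccc(F)cc2)cc1OC`: 15.4%

In a functional assay on the whole organism (artery, strain albino) with Rattus norvegicus as the target, with a stated time of 900 min, at a dose of 10 mg/kg by the oral route (a higher number here means more inhibition at the dose given (going by the name of the read-out), a lower number less inhibition), compound 1 gives 21%, the highest of the two numbers shown, although the single step of a number 5.6 percentage points lower from compound 1 to compound 2 (within the scatter) stays within the scatter. Compound 3 `CC1=C(C(=O)Nc2ccc(F)cc2)C(c2ccc([N+](=O)[O-])cc2)N=C(SCc2ccccc2Cl)N1` differs from compound 1 in one place: 4-nitrophenyl in place of 3,4-dimethoxyphenyl on a saturated ring carbon. Going by the values given here, no measured step touches this part of the shared core; the one step available, a number 5.6 percentage points lower from compound 1 to compound 2 (within the scatter), concerns the group on the sulfur-bound chain carbon, and it was small. With nothing pointing either way, the expected step is a number 3 percentage points lower from compound 1 to compound 3 (within the scatter), that is, none beyond the scatter. The estimate for compound 3 is 18%, with a range from 4% to 34%.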

Compound 3, a percentage reported as inhibition, in the whole organism at one dose (the size of the read-out at that dose, not a potency): 11.3%
The estimate for compound 3 lay 6.7 percentage points above the measured number, within the range that was stated.
By their numbers in this assay, from the lowest: compounds 3, 2 and 1 (each within the scatter of the next).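

Going by these compounds alone, this is the first step at this saturated ring carbon: 4-nitrophenyl in place of 3,4-dimethoxyphenyl gives, in this assay, a number 9.7 percentage points lower from compound 1 to compound 3 (within the scatter). Two quite different groups on this ring carbon therefore cannot be told apart at this dose. Nothing available explains the result.

As far as these compounds go, it remains open whether a plain phenyl or a 4-aminophenyl at this ring carbon would separate from compound 1. From the compounds shown here alone, it is also open whether 4-nitrophenyl would read the same with the 4-fluorophenyl of compound 2 on the sulfur-bound chain.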